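The source may report more compounds than this note shows. Statements on the series, on what has been measured and on what is new or still open speak of the compounds shown alone.

Working notes on the series. Compound 2 `Cc1cc(NC(=O)Cn2nnc(-c3ccc(F)c(F)c3)n2)n(C2CCCCC2)n1` and compound 1 `Cc1cc(NC(=O)Cn2nnc(-c3ccccn3)n2)n(C2CCCCC2)n1` share a core and differ only in the aromatic group attached to it. Among the measured compounds shown here, in an assay on HEK293 cells for activation of Kir3.1/Kir3.2 (Homo sapiens), read by thallium flux (on this read-out higher numbers stand for larger maximal responses and lower numbers for smaller maximal responses), compound 2 gives 93%, the higher of the two numbers measured so far, and compound 1 gives 81%. The step of a number 12 percentage points higher from compound 1 to compound 2 (beyond the scatter) came with 3,4-difluorophenyl in place of pyridin-2-yl on an aromatic carbon. Compound 3 `COc1cccc(-c2nnn(CC(=O)Nc3cc(C)nn3C3CCCCC3)n2)c1` is not yet measured; relative to compound 2 it carries 3-methoxyphenyl in place of 3,4-difluorophenyl on an aromatic carbon. For the measured compounds named here, the single measured step bears on this change only loosely: it shows that exchanging the aromatic group on that carbon shifted the maximal response by a modest amount, but 3-methoxyphenyl is neither of the two groups measured, so no direction can be read from it. For that reason a step that stays within the scatter, or at most a modest one downward, is expected, a number 8 percentage points lower from compound 2 to compound 3 (within the scatter). For compound 3 the expected value in this assay is 85%, with a range from 65% to 100%.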

Compound 3, largest response reached (Emax), in percent of the reference or control that the assay uses: 76%
Compound 3: the middle estimate sits 9 percentage points above what was measured; low and high end bracket the measured number.
By their numbers in this assay, from the lowest: compounds 3 and 1 (each within the scatter of the next); then compound 2.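

With a third group on the aromatic carbon of the five-membered ring, this assay shows that a substituted phenyl does not by itself carry the larger response: 3-methoxyphenyl in place of 3,4-difluorophenyl gives a number 17 percentage points lower from compound 2 to compound 3 (beyond the scatter) and so does not share what compound 2 shows. Against pyridin-2-yl, the same group gives a number 5 percentage points lower from compound 1 to compound 3 (within the scatter) and thus cannot be told apart from it on this read-out. Of the three groups, only 3,4-difluorophenyl now stands apart, with both of its steps beyond the scatter.

Still open, going by these compounds, is whether a single fluorine, a 3-aminophenyl or a 3-carboxyphenyl would keep the response of compound 2, and whether a saturated cyclohexyl on the same carbon would keep any of it. No measurement at hand accounts for the differences among these groups.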